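This account rests on a few compounds, and the source may have more. Where it says the series, first, only, none or still open, it means among the compounds named here.

Two analogues of the shared core have numbers. Compound 1 `O=C(CCCc1ccc2cccnc2n1)NCc1cnc(-c2ccc(F)c(C(F)(F)F)c2)nc1` gives 49 nM in a functional assay on CHO-K1 cells for antagonist activity at succinate receptor 1 (Homo sapiens), read by FLIPR and calcium flux; on this read-out higher numbers stand for weaker inhibition and lower numbers for stronger inhibition. Compound 2 `O=C(CCCc1ccc2cccnc2n1)NCc1cc(-c2cccc(Cl)c2)no1` gives 65 nM in this assay, the higher of the two numbers, with compound 1 lying within the scatter of it. Compound 3 `O=C(CCCc1ccc2cccnc2n1)NCc1cc(-c2ccc(F)c(C(F)(F)F)c2)no1` carries the change (4-fluoro-3-(trifluoromethyl)phenyl in place of 3-chlorophenyl on an aromatic carbon), which brings onto the core of compound 2 the aryl group seen in compound 1. With compound 1 giving 49 nM, only a small downward step, if any, is expected, and the step of a 1.4-fold lower number from compound 2 to compound 3 (0.16 log units; within the scatter) is estimated to stay within the scatter. Compound 3 is expected near 45 nM, between 18 nM and 110 nM.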

Compound 3, half-maximal inhibitory concentration: 35 nM
The estimate for compound 3 lay 1.3-fold (0.11 log units) above the measured number; low and high end bracket the measured number.
By their numbers in this assay, from the lowest: compounds 3, 1 and 2 (each within the scatter of the next).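

At this aromatic carbon next to the ring nitrogen, the step from 3-chlorophenyl to 4-fluoro-3-(trifluoromethyl)phenyl gives a 1.9-fold lower number from compound 2 to compound 3 (0.27 log units; within the scatter) in this assay, so the two aryl groups cannot be told apart here. The position accepts the entering group, with its four fluorine atoms and more heavy atoms, without a shift beyond the scatter. No measurement on hand accounts for this result.

Open, from the compounds shown here alone, is how an aryl group carrying an amine or a carboxylic acid would read at this carbon. Also open, going by these compounds, is whether a cyclohexyl or a plain methyl group could replace the aryl ring.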